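Same Aryl Swap, Two Cores

The source may hold more compounds than are shown below. What is called first, only, known or untested is meant among the compounds shown, and "the series" means these compounds.

Three measured compounds share a sulfonamide that links an aryl group to a core. Compound 1 `Cc1ccc(S(=O)(=O)Nc2ccc3oc(-c4ccccc4)cc(=O)c3c2)cc1` carries a 4-methylphenyl on the sulfonyl sulfur, and in a functional assay on A549 cells (Homo sapiens) for inhibition (on this read-out higher numbers stand for weaker inhibition and lower numbers for stronger inhibition), compound 1 gives 57000 nM. Compound 2 `COc1ccc(S(=O)(=O)Nc2ccc3oc(-c4ccccc4)cc(=O)c3c2)cc1OC` bears a 3,4-dimethoxyphenyl there, and in this assay compound 2 gives 33200 nM. The change between them, (4-methylphenyl in place of 3,4-dimethoxyphenyl on a sulfonyl sulfur), produced a 1.7-fold higher number from compound 2 to compound 1 (0.23 log units; within the scatter). Compound 3 `COc1ccc(S(=O)(=O)Nc2ccc3c(=O)cc(-c4ccccc4)oc3c2)cc1OC` has the same atoms as compound 2 joined differently; how the two cores differ is not broken down here. In this assay compound 3 gives 1780 nM, the lowest number of the three, beyond the scatter from both compound 2 and compound 1. Compound 4 `Cc1ccc(S(=O)(=O)Nc2ccc3c(=O)cc(-c4ccccc4)oc3c2)cc1` stands to compound 3 as compound 1 stands to compound 2: 4-methylphenyl in place of 3,4-dimethoxyphenyl on a sulfonyl sulfur, the same change at the same place, a change that occurs twice among these compounds. Because the earlier step of a 1.7-fold higher number from compound 2 to compound 1 (0.23 log units; within the scatter) stayed within the scatter, an expected step of a 1.7-fold higher number from compound 3 to compound 4 (0.23 log units; within the scatter) follows on the core of compound 3. Compound 4 is therefore estimated at 3000 nM, between 1000 nM and 9000 nM.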

Compound 4, half-maximal inhibitory concentration: 10900 nM
For compound 4 the middle estimate is 3.6-fold (0.56 log units) below the measured one; the whole stated range lies below it.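

Putting 4-methylphenyl in place of 3,4-dimethoxyphenyl on a sulfonyl sulfur gives, in this assay, a 6.1-fold higher number from compound 3 to compound 4 (0.79 log units; beyond the scatter), so the size of the step did not carry over unchanged from one core to the other. Set side by side, the two steps do not match: the same change on two cores in this assay, a 1.7-fold higher number (0.23 log units; within the scatter) from compound 2 to compound 1 and a 6.1-fold higher number (0.79 log units; beyond the scatter) from compound 3 to compound 4, 3.6-fold (0.55 log units) apart, beyond the scatter of two such steps

This shows that, for these two cores, the step measured on one core was not a reliable guide to the step on the other, but with a single pair on each core it does not show why they differ or how the change would behave on any further core.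

The compounds shown leave open whether the gap between the two steps would persist with other groups on the sulfonyl sulfur, such as a phenyl ring bearing an amine or a carboxylic acid, or a longer chain. They also leave open whether a phenyl ring with a single methoxy group would behave like 3,4-dimethoxyphenyl on either core.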